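Methoxy count on the core aryl of chalcone-bearing series

A few compounds are considered here, and "the series" means these few. Any claim that something is new, unique, unknown or untested is made for them only; others in the source may bear on it.

Measured so far:
compound 1 `COc1ccc(-c2cc(C(=O)/C=C/c3ccc(Cl)cc3)nc3cc(-c4ccccc4)nn23)cc1OC` 23700 nM
compound 2 `COc1ccc(-c2cc(/C=C/C(=O)c3ccc(OC)c(OC)c3)nc3cc(-c4ccccc4)nn23)cc1` 8700 nM
compound 3 `COc1ccc(C(=O)/C=C/c2cc(-c3ccc(OC)cc3)n3nc(-c4ccccc4)cc3n2)cc1` 6300 nM

In a functional assay on MDA-MB-231 cells (Homo sapiens) for antiproliferative activity, read by MTT assay, with a stated time of 24 h (on this read-out higher numbers stand for weaker inhibition and lower numbers for stronger inhibition), compound 2 stands second highest of the three numbers, with compound 3 nearest and compound 1 furthest off. The step to compound 4 `COc1ccc(C(=O)/C=C/c2cc(-c3ccc(OC)c(OC)c3)n3nc(-c4ccccc4)cc3n2)cc1OC` is methoxy in place of hydrogen on an aromatic carbon. Among the compounds with values here, no measured pair changes a methoxy at that place; the only single-place step is a 1.4-fold lower number from compound 2 to compound 3 (0.14 log units; within the scatter), which removes a methoxy elsewhere and stays within the scatter. Adding one methoxy at the core aryl is therefore expected to give little change in this assay, no more than the scatter. Compound 4 is expected near 7000 nM, between 3000 nM and 18000 nM, an expected step of a 1.2-fold lower number from compound 2 to compound 4 (0.09 log units; within the scatter).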

Compound 4, half-maximal inhibitory concentration: 2600 nM
Compound 4: the middle estimate sits 2.7-fold (0.43 log units) above what was measured; measured number below the stated range.
By their numbers in this assay, from the lowest: compound 4; then compounds 3 and 2 (each within the scatter of the next); then compound 1.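

In this assay, the change from 4-methoxyphenyl to 3,4-dimethoxyphenyl gives a 3.3-fold lower number from compound 2 to compound 4 (0.52 log units; beyond the scatter). This position therefore responds to an added methoxy beyond the scatter, unlike the methoxy elsewhere, whose removal gave a 1.4-fold lower number from compound 2 to compound 3 (0.14 log units; within the scatter), within the scatter. The compounds offer no measurement that accounts for this difference.

From the compounds shown here alone, whether the gain is specific to methoxy remains open, since a hydroxy group, an amine or a longer ethoxy chain at this place could separate it from any substituent there. Also open, going by these compounds, is whether the step carries over to the chlorophenyl chalcone of compound 1.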